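A few compounds are considered here, and "the series" means these few. Any claim that something is new, unique, unknown or untested is made for them only; others in the source may bear on it.

In an ADME assay on the whole organism (Rattus norvegicus, strain Sprague-Dawley) for pharmacokinetics, read by LC-MS (a higher number here means that more of the compound sits outside the plasma, a lower number that more of the compound stays in the plasma), compound 1 `N#Cc1ccc(S(=O)(=O)N2C[C@H](S(=O)(=O)c3ccc(Cl)cc3)[C@](O)(CO)C2)c(Cl)c1` gives 4.5 L/kg and compound 2 `N#Cc1ccc(S(=O)(=O)N2C[C@H](S(=O)(=O)c3ccc(Cl)cn3)[C@](O)(CO)C2)c(Cl)c1` gives 2 L/kg as the lower of the two numbers. The change to compound 3 `N#Cc1ccc(S(=O)(=O)N2C[C@H](S(=N)(=O)c3ccc(Cl)cc3)[C@](O)(CO)C2)c(Cl)c1`, not yet measured, is a group of 10 heavy atoms (6 carbon, 1 nitrogen, 1 oxygen, 1 sulfur, 1 chlorine; one six-membered aromatic ring of carbon only) in place of a group of 10 heavy atoms (5 carbon, 1 nitrogen, 2 oxygen, 1 sulfur, 1 chlorine; one six-membered aromatic ring with 1 hetero atom), on a saturated ring carbon with the rest of the structure unchanged. Within the data shown here, the only measured step bearing on this is a 2.3-fold lower number from compound 1 to compound 2 (0.35 log units; beyond the scatter) for an exchange of aromatic ring, modest in size. Compound 3 again has a six-membered aromatic ring of carbon only, so the reverse direction of a 2.3-fold lower number from compound 1 to compound 2 (0.35 log units; beyond the scatter) is expected. Among the measured compounds shown here, no measured compound holds the rest of the entering group, so only part of that step is expected to carry over. The expected step is a 1.5-fold higher number from compound 2 to compound 3 (0.18 log units; within the scatter) and no firm change beyond the scatter is claimed. Compound 3 is estimated at 3 L/kg with a range of 1.4 L/kg to 6 L/kg in this assay for now.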

Compound 3, volume of distribution at steady state: 3.2 L/kg
Compound 3: middle estimate off by 1.1-fold (0.03 log units), on the low side; the range from low to high includes it.
By their numbers in this assay, from the lowest: compounds 2, 3 and 1 (each within the scatter of the next, the first and the last beyond it).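

In this assay, replacing one sulfonyl oxygen with an imino nitrogen while keeping the 4-chlorophenyl ring gives a 1.4-fold lower number from compound 1 to compound 3 (0.15 log units; within the scatter), so this exchange on the saturated ring carbon brings no firm change in the read-out. The comparison with the pyridine compound gives a 1.6-fold higher number from compound 2 to compound 3 (0.20 log units; within the scatter), but that step alters the aromatic ring and the sulfur group together and cannot separate the two exchanges. Of the three steps in hand, only the ring exchange with the sulfonyl group kept, a 2.3-fold lower number from compound 1 to compound 2 (0.35 log units; beyond the scatter), lies beyond the scatter.

Still open, from the compounds shown here alone, is whether the imino nitrogen paired with the 5-chloropyridin-2-yl ring would give a number that differs from either neighbour, and what a methyl group on that nitrogen would do. No evidence at hand accounts for any of these numbers.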